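Fluoro on the pendant phenyl: second occurrence of one change

The source may report more compounds than this note shows. Statements on the series, on what has been measured and on what is new or still open speak of the compounds shown alone.

Compound 2 `Nc1ncnn2c([C@@H]3O[C@H](CO)[C@@H](O)[C@H]3O)cc(C#Cc3ccccc3)c12` bears a 2-phenylethynyl group on the shared core and in a functional assay on LN-229 cells (Homo sapiens) for antiproliferative activity, with a stated time of 72 h (a lower number here means a stronger inhibitor, a higher number a weaker inhibitor), compound 2 gives 88000 nM. Compound 1 `Nc1ncnn2c([C@@H]3O[C@H](CO)[C@@H](O)[C@H]3O)cc(C#Cc3ccc(F)cc3)c12` differs from it by fluoro in place of hydrogen on an aromatic carbon. In this assay compound 1 returns only a limit, > 100000 nM. The step of an at least 1.1-fold higher number from compound 2 to compound 1 (0.05 log units; that floor lies within the scatter) therefore has a floor only, due to the limit of > 100000 nM in this assay, at which 1 of the 3 values shown sits. Compound 3 `Nc1ncnn2c([C@@H]3O[C@H](CO)[C@@H](O)[C@H]3O)cc(-c3ccccc3)c12` has a different core; the difference is phenyl in place of 2-phenylethynyl on an aromatic carbon. In this assay compound 3 gives 75100 nM. The two cores compare as a 1.2-fold lower number from compound 2 to compound 3 (0.07 log units; within the scatter), and an at least 1.3-fold lower number from compound 1 to compound 3 (0.12 log units; that floor lies within the scatter) is likewise a floor. Compound 4 `Nc1ncnn2c([C@@H]3O[C@H](CO)[C@@H](O)[C@H]3O)cc(-c3ccc(F)cc3)c12` is not yet measured and differs from compound 3 by fluoro in place of hydrogen on an aromatic carbon, the same change as from compound 2 to compound 1, with the place described in identical words. A step of a 1.3-fold higher number from compound 3 to compound 4 (0.10 log units; within the scatter) is expected in this assay, given an at least 1.1-fold higher number from compound 2 to compound 1 (0.05 log units; that floor lies within the scatter) and compound 3 at 75100 nM. Compound 4 is thus estimated at 95000 nM, within 50000 nM to 200000 nM, with a real chance that only a limit is returned.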

Compound 4, half-maximal inhibitory concentration: 65600 nM
Compound 4: middle estimate off by 1.4-fold (0.16 log units), on the high side, and the stated range covers the measured number.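

In this assay, fluoro in place of hydrogen on the phenyl group gives a 1.1-fold lower number from compound 3 to compound 4 (0.06 log units; within the scatter), and the exchange of 2-phenylethynyl for 4-fluorophenyl gives a 1.3-fold lower number from compound 2 to compound 4 (0.13 log units; within the scatter), so neither step lies beyond the scatter. Carrying the change from one core to the other thus shows no step beyond the scatter on either core, but it does not show that the change acts alike on both: the same change on two cores in this assay, an at least 1.1-fold higher number (0.05 log units; that floor lies within the scatter) from compound 2 to compound 1 and a 1.1-fold lower number (0.06 log units; within the scatter) from compound 3 to compound 4; the limit leaves it open whether they differ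

Compound 1 returns only a limit, so an at least 1.5-fold lower number from compound 1 to compound 4 (0.18 log units; that floor lies within the scatter) is a floor and not a measured step: the limit of > 100000 nM in this assay, at which 1 of the 4 values shown sits.

Open, as far as these compounds go, is whether an amine or a carboxylic acid in place of fluoro, on the same aromatic carbon, would move the number beyond the scatter. Also open, from the compounds shown here alone, is whether the fluoro change would read the same with a longer chain in place of the phenyl or 2-phenylethynyl group on the shared core.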